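Bromine for methyl on a ring of inactive compounds

The source may hold more compounds than are shown below. What is called first, only, known or untested is meant among the compounds shown, and "the series" means these compounds.

Compound 3 `Cc1cccc(-n2nncc2CN2C(=O)C3(C(C#N)=C(N)Oc4c(N)cc5nc6ccccc6nc5c43)c3ccccc32)c1` is the starting point. In a functional assay on HCT-116 cells (Homo sapiens) for antiproliferative activity, read by MTT assay, with a stated time of 48 h (a higher number here means a weaker inhibitor, a lower number a stronger inhibitor), compound 3 gives > 50000 nM, which is a limit of the assay rather than a measured number. Two related compounds sit in the same place. Compound 1 `N#CC1=C(N)Oc2c(c3nc4ccccc4nc3c3ccccc23)C12C(=O)N(Cc1cnnn1-c1ccc(F)cc1)c1ccccc12` gives > 50000 nM in this assay, again only a limit. Compound 2 `Cc1ccc(-n2nncc2CN2C(=O)C3(C(C#N)=C(N)Oc4c3c3nc5ccccc5nc3c3ccccc43)c3ccccc32)c(C)c1` gives > 50000 nM, also a limit. Among the compounds with values here, the single comparison available, a step that the two limits leave unreadable from compound 1 to compound 2, therefore has no readable size, and the whole evidence comes down to the limit of > 50000 nM in this assay, at which 3 of the 3 values shown sit.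

Compound 4 `N#CC1=C(N)Oc2c(N)cc3nc4ccccc4nc3c2C12C(=O)N(Cc1cnnn1-c1cccc(Br)c1)c1ccccc12` differs from compound 3 by bromo in place of methyl on an aromatic carbon. Within the data shown here, no measured step touches this change, so there is nothing to say how large an effect it might have or in which direction; what is known is only that compound 3 and its two neighbours are all held at the limit. On that basis compound 4 is expected to remain at the limit as well, with a step that the limit leaves unreadable from compound 3 to compound 4 that is not beyond the scatter. The estimate for compound 4 is 60000 nM, within a range from 20000 nM to 200000 nM.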

Compound 4, half-maximal inhibitory concentration: 26100 nM
Estimate against measurement, compound 4: 2.3-fold (0.36 log units) above; the range from low to high includes it.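

Compound 4 is the only compound shown that gives a measured number in this assay, so this place on the ring can now be tied to a readable value. Compound 3 gives > 50000 nM, which is a limit and not a number. Bromo in place of methyl therefore gives an at least 1.9-fold lower number from compound 3 to compound 4 (0.28 log units; that floor lies within the scatter), so the true step may be larger, but the part that can be read does not by itself pass the usual scatter.

Going by these compounds, whether a hydrogen, a chlorine, a methoxy group or an amine at this place on the ring would give a similar number remains open. Also open is whether bromo would give a measurable value on the core of compound 1, where the picture so far is only this: the limit of > 50000 nM in this assay, at which 3 of the 4 values shown sit.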